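The source may hold more compounds than are shown below. What is called first, only, known or untested is meant among the compounds shown, and "the series" means these compounds.

Working notes on the solubility series. In a physicochemical assay for solubility, read by spectrophotometry, in phosphate buffer, with a stated time of 2 h, at pH 7.4 (on this read-out higher numbers stand for higher solubility and lower numbers for lower solubility), compound 1 `COc1ccc2[nH]c(C(=O)N3CC(=O)N(Cc4ccccc4)[C@@H](CCc4ccccc4)C3)cc2c1` gives 4400 nM. Compound 2 `COc1ccc2[nH]c(C(=O)N3CC(=O)N(Cc4ccccc4)[C@@H](CN4CCN(S(=O)(=O)c5ccccc5)CC4)C3)cc2c1` gives 16900 nM in this assay, and compound 3 `COc1ccc2[nH]c(C(=O)N3CC(=O)N(c4ccccc4)[C@@H](Cc4ccccc4)C3)cc2c1` gives 36100 nM. Compound 1 therefore stands lowest of the three numbers; the step up to compound 2 lies beyond the scatter, and the step up to compound 3 lies further beyond it.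

Compound 4 `COc1ccc2[nH]c(C(=O)N3CC(=O)N(Cc4ccccc4)[C@@H](N4[C@H](C)CCC[C@@H]4C)C3)cc2c1` has not been measured. It differs from compound 1 by 2,6-dimethylpiperidin-1-yl in place of phenethyl on a saturated ring carbon: 2,6-dimethylpiperidin-1-yl replaces phenethyl on a saturated ring carbon of the shared core. For the measured compounds named here, no step between measured compounds matches this change, so the size of the step is not known from direct comparison. The expectation is that compound 4 moves upward in this assay from compound 1, by a step of about a 3.4-fold higher number from compound 1 to compound 4 (0.53 log units; beyond the scatter), beyond the scatter, because compound 2, which also carries a saturated nitrogen ring in this region, gives 16900 nM. The estimate for compound 4 in this assay is 15000 nM, within a range of 5000 nM to 45000 nM.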

Compound 4, solubility: 100000 nM
Compound 4: the middle estimate sits 6.7-fold (0.82 log units) below what was measured, and the stated range ends below it.
By their numbers in this assay, from the lowest: compound 1; then compound 2; then compound 3; then compound 4.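

In this assay the exchange of phenethyl for 2,6-dimethylpiperidin-1-yl on a saturated ring carbon of the shared core gives a 23-fold higher number from compound 1 to compound 4 (1.36 log units; beyond the scatter) and is a large step, so the read-out is highly sensitive to the group at this position. The two groups match in heavy-atom count, so this step goes with a change in the type of group rather than in that count: a six-membered aromatic ring of carbon only gives way to a non-aromatic ring with one hetero atom and two defined stereocentres. Nothing available here accounts for the size of the step.

From the compounds shown here alone, whether it follows from the ring nitrogen, the two methyl groups or the defined stereocentres stays open, since this single pair cannot separate them. A plain piperidin-1-yl or a morpholin-4-yl on the same ring carbon would bear directly on that question.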